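This account rests on a few compounds, and the source may have more. Where it says the series, first, only, none or still open, it means among the compounds named here.

Measured so far in a functional assay on L1210 cells (Mus musculus) for inhibition, read by MTT assay, with a stated time of 72 h; a higher number here means a weaker inhibitor, a lower number a stronger inhibitor:
- compound 1 `COc1cc(NC(C)CCCNC(=O)Nc2ccc(Br)cc2)c2ncccc2c1`: 18000 nM
- compound 2 `COc1cc(NC(C)CCCNC(=O)NNC(=O)Nc2ccc(Br)cc2)c2ncccc2c1`: 51000 nM

Compound 2 holds the higher of the two numbers, 51000 nM. Compound 3 `COc1cc(NC(C)CCCNC(=O)Nc2cccc(O)c2)c2ncccc2c1` differs from it by one change: 3-hydroxyphenyl in place of ((4-bromophenyl)carbamoyl)amino on an amide-type nitrogen. The 3-hydroxyphenyl group takes the place of ((4-bromophenyl)carbamoyl)amino on an amide-type nitrogen.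

Among the compounds with values here, only one measured step bears on this: a 2.8-fold higher number from compound 1 to compound 2 (0.45 log units; beyond the scatter). That modest step brought in the same ((4-bromophenyl)carbamoyl)amino group that now leaves. Within the data shown here, no measured step covers 3-hydroxyphenyl, so its contribution is unknown and the range stays wide. With that group gone, a return towards compound 1, at 18000 nM, is expected. The expected move is to a lower number, of similar modest size: a 2.3-fold lower number from compound 2 to compound 3 (0.37 log units; beyond the scatter). For compound 3 the estimated value is 22000 nM, with an expected range of 8000 nM to 60000 nM.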

Compound 3, half-maximal inhibitory concentration: 25000 nM
The estimate for compound 3 lay 1.1-fold (0.06 log units) below the measured number, within the range that was stated.
By their numbers in this assay, from the lowest: compounds 1 and 3 (each within the scatter of the next); then compound 2.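

In this assay the exchange of ((4-bromophenyl)carbamoyl)amino for 3-hydroxyphenyl on the amide-type nitrogen gives a 2.0-fold lower number from compound 2 to compound 3 (0.31 log units; beyond the scatter) and so moves the number back towards that of compound 1. Exchanging 4-bromophenyl for 3-hydroxyphenyl at this same nitrogen gives a 1.4-fold higher number from compound 1 to compound 3 (0.14 log units; within the scatter) and so leaves these two aromatic groups unseparated in this read-out, which shows that this position accepts either without a change beyond the scatter. Nothing measured here bears on the reason for either step.

On these data alone, it remains open whether a phenyl ring carrying an amine or a carboxylic acid would move the number beyond the scatter from compound 1 and compound 3. As far as these compounds go, the effect of a longer chain between the shared core and the carbonyl is equally open.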